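This account rests on a few compounds, and the source may have more. Where it says the series, first, only, none or still open, it means among the compounds named here.

Compound 3 `COc1ccc(Cn2c(CCc3ccccc3)nnc2[C@H](NC(=O)c2ccccn2)c2c[nH]c3ccccc23)cc1` stands lowest of the three numbers measured: in an in vitro assay on LLC-PK1 cells for displacement of a labelled ligand from growth hormone secretagogue receptor type 1 (Homo sapiens) (a lower number here means a stronger inhibitor, a higher number a weaker inhibitor), compound 3 gives 0.7 nM. Its nearest neighbour, compound 2 `COc1ccc(Cn2c(CCc3c[nH]c4ccccc34)nnc2[C@H](NC(=O)c2ccccn2)c2c[nH]c3ccccc23)cc1`, gives 1.9 nM in this assay, and the furthest, compound 1 `CCc1ccc(Cn2c(CCc3ccccc3)nnc2[C@H](NC(=O)c2ccccn2)c2c[nH]c3ccccc23)cc1`, gives 67 nM. The two measured steps, a 96-fold lower number from compound 1 to compound 3 (1.98 log units; beyond the scatter) and a 2.7-fold lower number from compound 2 to compound 3 (0.43 log units; beyond the scatter), both alter groups away from the amide and leave the ring on the carbonyl carbon untouched. Compound 4 `COc1ccc(Cn2c(CCc3ccccc3)nnc2[C@H](NC(=O)c2ccncc2)c2c[nH]c3ccccc23)cc1` differs from compound 3 by pyridin-4-yl in place of pyridin-2-yl on a carbonyl carbon. Among the measured compounds shown here, no measured step speaks to this change, so there is nothing in the data to say how far the number should move, and the expectation rests on compound 3 alone. Since the rest of the structure is unchanged, the step of a 2.9-fold higher number from compound 3 to compound 4 (0.46 log units; beyond the scatter) is expected to be small, most likely a mild weakening rather than a gain. Compound 4 is therefore estimated at 2 nM in this assay, within a range of 0.5 nM to 8 nM.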

Compound 4, half-maximal inhibitory concentration: 220 nM
Compound 4: middle estimate off by 110-fold (2.04 log units), on the low side; measured number outside the range, above it.
By their numbers in this assay, from the lowest: compound 3; then compound 2; then compound 1; then compound 4.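

Among the compounds shown here, on the carbonyl carbon of the amide, the identity of the ring matters far more than the earlier compounds could show: in this assay, pyridin-4-yl in place of pyridin-2-yl gives a 310-fold higher number from compound 3 to compound 4 (2.50 log units; beyond the scatter). The two groups have the same heavy atoms, the same single hetero atom in a six-membered aromatic ring, and the same counts of donors and acceptors, so these counts do not separate them; the large step comes with a change in how the same atoms are joined. Nothing available explains why this rearrangement carries such a cost.

Going by these compounds, it remains open whether pyridin-3-yl or a plain phenyl on this carbonyl carbon would stand nearer compound 3 or compound 4. On these data alone, it is also open whether the step would stay as large with the ethyl group of compound 1 or the 1H-indol-3-yl group of compound 2 in place.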